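Methoxy for fluoro on two related aryl pairs

This account rests on a few compounds, and the source may have more. Where it says the series, first, only, none or still open, it means among the compounds named here.

Four compounds share one central unit and differ in how the aryl ring is attached and in the group it carries. Compound 1 `Cn1cc(-c2cnc3ccnc(NC(=O)c4ccc(F)cc4)c3c2)cn1` carries a 4-fluorophenyl group; in a functional assay on A549 cells (Homo sapiens) for antiproliferative activity, read by MTT assay, with a stated time of 48 h (a lower number here means a stronger inhibitor, a higher number a weaker inhibitor), compound 1 gives only a limit, > 50000 nM. Compound 2 `COc1ccc(C(=O)Nc2nccc3ncc(-c4cnn(C)c4)cc23)cc1` is its methoxy counterpart; in this assay compound 2 likewise gives only a limit, > 50000 nM. The change between them is methoxy in place of fluoro on an aromatic carbon and the resulting step is a step that the two limits leave unreadable from compound 1 to compound 2, which is not readable because the limit of > 50000 nM in this assay, at which 2 of the 3 values shown sit, holds both of its values. Going by the values given here, compound 3 `Cn1cc(-c2cnc3ccnc(NCc4ccc(F)cc4)c3c2)cn1` carries the 4-fluorophenyl group on a different core; in this assay compound 3 gives 5200 nM, the only number in the set. The difference between the core of compound 1 and the core of compound 3 is not broken down here. Compound 4 `COc1ccc(CNc2nccc3ncc(-c4cnn(C)c4)cc23)cc1`, not yet measured, applies the same change to compound 3: methoxy in place of fluoro on an aromatic carbon. The place is described in identical words for both pairs, so this is the same change. With the earlier step unreadable, the expectation for compound 4 rests on compound 3 alone and on the change touching a single place on the ring. The step expected here, a 1.2-fold higher number from compound 3 to compound 4 (0.06 log units; within the scatter), is estimated as small. Compound 4 is estimated at 6000 nM, with a range from 2000 nM to 20000 nM.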

Compound 4, half-maximal inhibitory concentration: > 50000 nM
Compound 4 was reported as a limit; the forecaster's own chance of this, stated with the estimate: 15%; middle value at least 8.3-fold (0.92 log units) away from the limit.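

Methoxy in place of fluoro on an aromatic carbon gives an at least 9.6-fold higher number from compound 3 to compound 4 (0.98 log units; beyond the scatter) in this assay, so on the core of compound 3 the change from 4-fluorophenyl to 4-methoxyphenyl clearly weakens antiproliferative activity, and the printed size is only a lower bound on the true step. The same change on the core of compound 1 cannot be read, and neither can any comparison of its size between the two cores, as both partners of that pair sit at one limit: the limit of > 50000 nM in this assay, at which 3 of the 4 values shown sit. Transfer of the change from one core to another is therefore neither supported nor contradicted, as the single readable step belongs to one core alone and says nothing about how the change behaves on the core of compound 1.

The compounds shown leave open whether the loss is specific to methoxy or would follow any replacement of fluoro at this place on the ring, for instance by an amine, a carboxylic acid or a longer chain such as butoxy. Also open, from the compounds shown here alone, is whether any such group would bring the core of compound 1 to a readable number in this assay.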